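Adding methyl to compound 2

The compounds below may be only part of what the source reports. "The series", "measured", "known", "first", "only" and "open" are said of these compounds alone.

Measured so far in a functional assay on the whole organism for antagonist activity, with Mus musculus as the target (a higher number here means that more compound is needed for the effect, a lower number that less compound is needed), with these compounds:
compound 1 `CCC(=O)N(c1ccc(C)cc1)C1CCCC1N(C)C` gives 10 mg/kg; 10 mg/kg (2 entries)
compound 2 `CCC(=O)N(c1cccc(Cl)c1)C1CCCC1N(C)C` gives 0.2 mg/kg

Compound 2 has a single value, and it lies well under the two matching entries for compound 1, so less compound is needed for the effect. Compound 3 `CCC(=O)N(c1ccc(C)c(Cl)c1)C1CCCC1N(C)C` keeps the shared core and the chloro group of compound 2. The change is methyl in place of hydrogen on an aromatic carbon with methyl in place of hydrogen on an aromatic carbon, ortho to a chloro group and para to a large group.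

Within the data shown here, no measured pair differs in one place only, so the size of this step has no direct precedent. Among the measured compounds shown here, compound 1 carries a methyl group but no chloro group and gives 10 mg/kg; 10 mg/kg (2 entries) in this assay for the only comparison at hand. On that slim basis, a modest rise in the dose needed is expected. The estimated change is a 3.0-fold higher number from compound 2 to compound 3 (0.48 log units; beyond the scatter) in this reading. For compound 3 the expected value is 0.6 mg/kg with an estimated range from 0.1 mg/kg to 3 mg/kg in this assay at this stage.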

Compound 3, dose for half-maximal effect: 0.6 mg/kg
Compound 3: middle estimate and measured number agree at the digits printed; measured number inside the range.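

In this assay, among these compounds, methyl in place of hydrogen on an aromatic carbon, ortho to a chloro group and para to a large group, gives a 3.0-fold higher number from compound 2 to compound 3 (0.48 log units; beyond the scatter), the first single-place step. This position therefore accepts a methyl group at a modest cost, with the dose still in the same low range rather than near the level of the analogue lacking the chloro group. That analogue, compound 1, carries the methyl group alone and gives 10 mg/kg; 10 mg/kg (2 entries), whereas compound 3 carries both groups and gives 0.6 mg/kg, so the presence of the methyl group does not by itself bring the high dose seen for compound 1.

Nothing available on these compounds bears on what lies behind this step.

Going by these compounds, whether the modest rise depends on the size of the new group remains open, since an ethyl group or a methoxy group at this carbon would be needed to tell. Also open, on these data alone, is whether the same step holds when a fluoro group or a trifluoromethyl group replaces the chloro group.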